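Urea-linked anilines on a shared core: methoxy versus nitro

The compounds below may be only part of what the source reports. "The series", "measured", "known", "first", "only" and "open" are said of these compounds alone.

Two compounds carrying the same urea-linked aniline on a quinazoline-free description of "the shared core" have been measured, and a third awaits its number. Compound 1, `COc1ccc(NC(=O)Nc2cccc(CNc3ncnc4ccccc34)c2)cc1`, is the plainer of the two measured structures; in a functional assay on MGC-803 cells (Homo sapiens) for antiproliferative activity, read by MTT assay (on this read-out higher numbers stand for weaker inhibition and lower numbers for stronger inhibition), compound 1 gives 27300 nM. Compound 2, `COc1ccc(NC(=O)Nc2cccc(CNc3ncnc4cc(OC)c(OC)cc34)c2)cc1`, adds two methoxy groups to the core, and in this assay compound 2 gives 12300 nM. Compound 2 therefore stands as the lower of the two numbers, with compound 1 sitting at a gap that falls beyond the usual scatter of such measurements.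

Compound 3, `COc1cc2ncnc(NCc3cccc(NC(=O)Nc4ccc([N+](=O)[O-])cc4)c3)c2cc1OC`, keeps the core of compound 2 and changes only the far end of the urea: nitro in place of methoxy on an aromatic carbon, placed on an aromatic carbon of a six-membered aromatic ring of carbon only, para to a large group. Among the measured compounds shown here, no measured pair shows this exchange, so any expectation rests on compound 2 alone. The step from compound 2 to compound 3 is expected to be modest, at most slightly toward lower numbers, as a 1.5-fold lower number from compound 2 to compound 3 (0.19 log units; within the scatter). Compound 3 is therefore estimated at 8000 nM, within a range from 3000 nM to 20000 nM.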

Compound 3, half-maximal inhibitory concentration: 8120 nM
Estimate against measurement, compound 3: 1.0-fold (0.01 log units) below; measured number inside the range.
By their numbers in this assay, from the lowest: compounds 3 and 2 (each within the scatter of the next); then compound 1.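

In this assay, nitro in place of methoxy on an aromatic carbon, para to a large group, gives a 1.5-fold lower number from compound 2 to compound 3 (0.18 log units; within the scatter), so at this position the two groups cannot be told apart by this read-out. Compounds 1 and 2 both carry the 4-methoxyphenyl group, so they gave no reading of this end of the urea; compound 3 supplies the first. It shows that 4-nitrophenyl can stand in place of 4-methoxyphenyl on the core of compound 2 with no change beyond the usual scatter, even though the exchange puts 3 heavy atoms where 2 stood. Nothing shown here offers an explanation for this result.

The compounds shown leave open whether an amine, a carboxylic acid or a chlorine atom at the same place would give a number clearly apart from those of compound 2 and compound 3. They also leave open whether the exchange of methoxy for nitro would read the same on the plainer core of compound 1.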